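The compounds below may be only part of what the source reports. "The series", "measured", "known", "first", "only" and "open" are said of these compounds alone.

Measured so far:
- compound 1, `COc1ncnc2c1ncn2[C@@H]1O[C@H](CO[Si](C)(C)C(C)(C)C)[C@@]2(OS(=O)(=O)C=C2N)[C@H]1O[Si](C)(C)C(C)(C)C`, gives in a functional assay on MT4 cells (Homo sapiens) for cytotoxicity (on this read-out higher numbers stand for lower toxicity in this test and lower numbers for higher toxicity in this test), a value of 21000 nM
- compound 2, `CNc1ncnc2c1ncn2[C@@H]1O[C@H](CO[Si](C)(C)C(C)(C)C)[C@@]2(OS(=O)(=O)C=C2N)[C@H]1O[Si](C)(C)C(C)(C)C`, gives in this assay a value of 14000 nM
- compound 3, `CC(C)(C)[Si](C)(C)OC[C@H]1O[C@@H](n2cnc3cncnc32)[C@H](O[Si](C)(C)C(C)(C)C)[C@]12OS(=O)(=O)C=C2N`, gives in this assay a value of 13000 nM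

All three compounds share one core and differ only in a single group on the aromatic ring system. Compound 3 sits among these three numbers with no clear separation: a 1.6-fold lower number from compound 1 to compound 3 (0.21 log units; within the scatter) and a 1.1-fold lower number from compound 2 to compound 3 (0.03 log units; within the scatter), and likewise a 1.5-fold lower number from compound 1 to compound 2 (0.18 log units; within the scatter). None of these steps is larger than the scatter of repeated measurements.

Compound 4, `CC(C)(C)[Si](C)(C)OC[C@H]1O[C@@H](n2cnc3ccccc32)[C@H](O[Si](C)(C)C(C)(C)C)[C@]12OS(=O)(=O)C=C2N`, is the next candidate. Its change from compound 3 is a group of 9 heavy atoms (7 carbon, 2 nitrogen; one five-membered aromatic ring with 2 hetero atoms, one six-membered aromatic ring of carbon only) in place of a group of 9 heavy atoms (5 carbon, 4 nitrogen; one five-membered aromatic ring with 2 hetero atoms, one six-membered aromatic ring with 2 hetero atoms), on a saturated ring carbon. Among the measured compounds shown here, no measured step swaps the whole ring system in this way; the measured steps only exchanged a small substituent on it, and all of them stayed within the scatter. On that basis compound 4 is expected to move little, if at all, in this assay, so the step is estimated as no change at the digits printed from compound 3 to compound 4 (within the scatter). The value for compound 4 is estimated at 13000 nM, with a range from 5000 nM to 35000 nM.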

Compound 4, half-maximal cytotoxic concentration: 15000 nM
For compound 4 the middle estimate is 1.2-fold (0.06 log units) below the measured one, within the range that was stated.
By their numbers in this assay, from the lowest: compounds 3, 2, 4 and 1 (each within the scatter of the next).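

Until now only a small substituent on the aromatic ring system had changed; here the whole ring system on the saturated ring carbon, next to the ring oxygen, is exchanged for 1H-benzimidazol-1-yl, with a six-membered aromatic ring of carbon only. In this assay this larger change gives a 1.2-fold higher number from compound 3 to compound 4 (0.06 log units; within the scatter) and stays equally small against the substituted compounds, with a 1.1-fold higher number from compound 2 to compound 4 (0.03 log units; within the scatter) and a 1.4-fold lower number from compound 1 to compound 4 (0.15 log units; within the scatter), so across these four compounds the hetero atoms of the six-membered ring make no readable difference to this number. Nothing measured here explains why the number holds steady.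

On these data alone, whether a carboxylic acid or a longer alkyl chain on the carbon-only six-membered ring would move the number beyond the scatter remains open. As far as these compounds go, all four compounds also keep the rest of the shared core, so the same exchange on a different core remains untested here.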